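Extending the Carbamate Side Chain of Compound 1

The compounds below may be only part of what the source reports. "The series", "measured", "known", "first", "only" and "open" are said of these compounds alone.

Measured compounds:
compound 1, `CC(C)[C@H](NC(=O)c1cc(Cl)ccc1OCCNC(=O)O)C(=O)Nc1ccc([N+](=O)[O-])cc1Cl`: > 10000 nM
compound 2, `CC(C)COC(=O)NCCOc1ccc(Cl)cc1C(=O)N[C@H](C(=O)Nc1ccc([N+](=O)[O-])cc1Cl)C(C)C`: 10100 nM

In a functional assay on MCF7 cells (Homo sapiens) for inhibition, read by MTT assay, with a stated time of 72 h (on this read-out higher numbers stand for weaker inhibition and lower numbers for stronger inhibition), compound 1 reaches only a limit, > 10000 nM. Compound 2 gives 10100 nM in this assay. The step that the limit leaves unreadable from compound 1 to compound 2 cannot be read because of the limit of > 10000 nM in this assay, at which 1 of the 2 values shown sits. Compound 3, `CC(C)[C@H](NC(=O)c1cc(Cl)ccc1OCCCCNC(=O)OC(C)(C)C)C(=O)Nc1ccc([N+](=O)[O-])cc1Cl`, differs from compound 1 by 2-((tert-butoxycarbonyl)amino)ethyl in place of carboxyamino on a saturated chain carbon, two bonds along the chain from an oxygen on an aromatic ring. No readable measured step bears on this change, and compound 2 sits close to the limit as well, so no step beyond the scatter is expected in this assay. Compound 3 is estimated at 15000 nM, within 5000 nM to 50000 nM, a step that the limit leaves unreadable from compound 1 to compound 3 that is expected to stay near the limit.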

Compound 3, half-maximal inhibitory concentration: > 10000 nM
Compound 3 gave a limit, no number; the forecaster's own chance of this, stated with the estimate: 65%; the middle value does not contradict the limit.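

Compound 3 reaches only a limit, > 10000 nM, in this assay. No step from compound 1 or compound 2 to compound 3 can be read: the limit of > 10000 nM in this assay, at which 2 of the 3 values shown sit.

On these data alone, whether 2-((tert-butoxycarbonyl)amino)ethyl in place of carboxyamino changes inhibition at all stays open.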